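The source may hold more compounds than are shown below. What is called first, only, known or untested is meant among the compounds shown, and "the series" means these compounds.

In a functional assay (Homo sapiens) for inhibition of Nucleic Acid, tested at 100 uM (on this read-out higher numbers stand for more inhibition at the one concentration tested (going by the name of the read-out) and lower numbers for less inhibition), compound 3 `CN(C)c1nccc2c1ncn2[C@H]1C[C@H](O)[C@@H](CO)O1` gives 0%, the lowest of the three numbers shown, though its gap to compound 2 stays within the scatter: compound 2 `OC[C@H]1O[C@@H](n2cnc3c(S)nccc32)C[C@@H]1O` gives 10% and compound 1 `Nc1nccc2c1ncn2[C@H]1C[C@H](O)[C@@H](CO)O1` gives 18%. The step of a number 10 percentage points lower from compound 2 to compound 3 (within the scatter) lies within the scatter, while a number 18 percentage points lower from compound 1 to compound 3 (beyond the scatter) goes beyond it. Compound 4 `CSc1nccc2c1ncn2[C@H]1C[C@H](O)[C@@H](CO)O1` differs from compound 3 by methylsulfanyl in place of dimethylamino on an aromatic carbon. The measured step that bears on this most closely is the one from sulfanyl to dimethylamino, a number 10 percentage points lower from compound 2 to compound 3 (within the scatter), which was small; reversing it and adding a methyl to the sulfur suggests at most a small rise. Compound 4 is therefore expected to give about 8%, in the range -5% to 22%, an estimated step of a number 8 percentage points higher from compound 3 to compound 4 (within the scatter) that would stay within the scatter.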

Compound 4, a percentage reported as inhibition, at one concentration (the size of the read-out at that concentration, not a potency): 36%
The estimate for compound 4 lay 28 percentage points below the measured number; the measured number lies above the stated range.
By their numbers in this assay, from the lowest: compounds 3, 2 and 1 (each within the scatter of the next, the first and the last beyond it); then compound 4.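

At this aromatic carbon the read-out in this assay can move well upward: methylsulfanyl in place of dimethylamino gives a number 36 percentage points higher from compound 3 to compound 4 (beyond the scatter) and stands above the amino group too, with a number 18 percentage points higher from compound 1 to compound 4 (beyond the scatter) as the first rise over compound 1 among these compounds. A single methyl on the sulfur is enough for a step beyond the scatter, a number 26 percentage points higher from compound 2 to compound 4 (beyond the scatter), so the sulfanyl and methylsulfanyl groups are not interchangeable here. Nothing available explains this rise. Going by these compounds, whether a longer chain on the sulfur, such as ethylsulfanyl, goes further remains open, as does whether methoxy or methylamino on this carbon behaves like methylsulfanyl.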